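A nitro group added to compound 3

The source may hold more compounds than are shown below. What is called first, only, known or untested is meant among the compounds shown, and "the series" means these compounds.

Measured in a functional assay on KB cells (Homo sapiens) for inhibition, read by MTT assay, with a stated time of 24 h, tested at 100 ug/mL; on this read-out lower numbers stand for less inhibition of growth and higher numbers for more inhibition of growth at the one concentration tested:
compound 1 `O=C(CCCCC1CCSS1)Nc1ccc([N+](=O)[O-])c(C(F)(F)F)c1` gives 49.5%
compound 2 `O=C(CCCCC(S)CCS)Nc1ccccc1` gives 15.8%
compound 3 `O=C(CCCCC(S)CCS)Nc1cccc(C(F)(F)F)c1` gives 30.5%

Compound 3, at 30.5%, stands second highest of the three, beyond the scatter from both compound 2 and compound 1. Compound 4 `O=C(CCCCC(S)CCS)Nc1ccc([N+](=O)[O-])c(C(F)(F)F)c1` differs from compound 3 by one change, nitro in place of hydrogen on an aromatic carbon. Among the measured compounds shown here, only one measured step bears on this, a number 14.7 percentage points higher from compound 2 to compound 3 (beyond the scatter), a modest rise with trifluoromethyl in place of hydrogen. For the measured compounds named here, no nitro step has been measured, but compound 1, the only measured compound with a nitro, reaches 49.5%. A similar modest rise is expected in this assay, going by the step of a number 14.7 percentage points higher from compound 2 to compound 3 (beyond the scatter). For compound 4 the estimated value is 43%, with an expected range from 28% to 60%. The expected change is a number 12.5 percentage points higher from compound 3 to compound 4 (beyond the scatter).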

Compound 4, percent growth inhibition at one concentration: 95.5%
Compound 4: middle estimate off by 52.5 percentage points, on the low side; the whole stated range lies below it.
By their numbers in this assay, from the lowest: compound 2; then compound 3; then compound 1; then compound 4.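

In this assay, nitro on this aromatic carbon, ortho to a trifluoromethyl group and para to a large group, gives a number 65 percentage points higher from compound 3 to compound 4 (beyond the scatter), so this position tolerates the change and responds strongly to it. With the nitro in place, the open chain in place of the five-membered non-aromatic ring gives a number 46 percentage points higher from compound 1 to compound 4 (beyond the scatter), so the size of the response also depends on the other end of the molecule. Nothing at hand accounts for either step. The compounds shown leave open whether a nitrile or an amine on this carbon would give a similar step. They also leave open whether nitro would give such a step without the trifluoromethyl group.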